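This account rests on a few compounds, and the source may have more. Where it says the series, first, only, none or still open, it means among the compounds named here.

Working notes on the series. Of the compounds shown here, two have been measured in an assay on isolated protein for inhibition of Aromatase (Homo sapiens), read by ELISA, using NADPH, with a stated time of 24 h (on this read-out lower numbers stand for stronger inhibition and higher numbers for weaker inhibition), so far. Compound 1 `Clc1ccc(-c2[nH]c3cc(Cl)ccc3c2Cn2cncn2)cc1` carries chloro at both ends of the shared core; in this assay compound 1 gives 208 nM. Compound 2 `COc1ccc(-c2[nH]c3cc(F)ccc3c2Cn2cncn2)cc1` carries a methoxy-substituted aryl group and fluoro on the fused system; in this assay compound 2 gives 14.1 nM. Compound 2 stands lowest of the two numbers, and the gap to compound 1 lies beyond the scatter. Compounds 1 and 2 differ in two places at once, so what the two values show cannot be assigned to either change alone.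

Compound 3 `COc1ccc(-c2[nH]c3cc(Cl)ccc3c2Cn2cncn2)cc1` is not yet measured. It differs from compound 2 in one place only: chloro in place of fluoro on an aromatic carbon. For the measured compounds named here, no single-point step has been measured, so the size of this step cannot be read from any pair already in hand. The expectation for the step from compound 2 to compound 3 is a 1.4-fold higher number from compound 2 to compound 3 (0.15 log units; within the scatter), a small change, if any, within or near the scatter. Compound 3 is thus estimated at 20 nM, with a range from 7 nM to 60 nM.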

Compound 3, half-maximal inhibitory concentration: 197 nM
The estimate for compound 3 lay 9.9-fold (0.99 log units) below the measured number; the measured number lies above the stated range.
By their numbers in this assay, from the lowest: compound 2; then compounds 3 and 1 (each within the scatter of the next).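

For the compounds shown here, this is the first single-place reading at this position, on an aromatic carbon of a six-membered aromatic ring of carbon only, part of a fused or bridged system of two rings: with the methoxy-substituted aryl group held constant, chloro in place of fluoro gives a 14-fold higher number from compound 2 to compound 3 (1.15 log units; beyond the scatter) in this assay and so counts as a large step. With chloro held on the fused system, methoxy in place of chloro on the aryl group gives a 1.1-fold lower number from compound 1 to compound 3 (0.02 log units; within the scatter) in the same read-out, which places compound 1 and compound 3 within the scatter of each other and shows that, among these chloro compounds, the aryl exchange does not separate the values. No measurement in hand gives a reason for the size of the halogen step at this position.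

The compounds shown leave open whether the low value of compound 2 is specific to fluoro, or whether hydrogen, methyl or a nitrile at the same carbon would give a number near that of compound 2 or near that of compound 3. They also leave open whether the methoxy and chloro aryl groups stay within the scatter of each other when fluoro sits on the fused system.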